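The compounds below may be only part of what the source reports. "The series", "measured", "known", "first", "only" and "open" are said of these compounds alone.

Measured so far:
compound 1 `COc1ccc2[nH]cc(-c3nc(C(=O)Nc4cc(OC)c(OC)c(OC)c4)cs3)c2c1` — > 100000 nM
compound 2 `O=C(Nc1ccccc1)c1csc(-c2cn(Cc3ccc(Cl)cc3)c3ccccc23)n1` — 50500 nM

In a functional assay on MDA-MB-231 cells (Homo sapiens) for cytotoxicity, read by MTT assay, with a stated time of 48 h, in the absence of a further agent (a lower number here means a stronger inhibitor, a higher number a weaker inhibitor), compound 1 gives only a limit of the measurement, > 100000 nM. This places compound 1 at the limit of > 100000 nM in this assay, at which 1 of the 2 values shown sits. In this assay compound 2 gives 50500 nM, a number rather than a limit. Compound 3 `COc1cc(NC(=O)c2csc(-c3c[nH]c4ccc(F)cc34)n2)cc(OC)c1OC` differs from compound 1 by one change, (fluoro in place of methoxy on an aromatic carbon). Going by the values given here, no measured pair shows what this change does, so the expected step in this assay is none beyond the scatter, in either direction. Compound 3 is therefore expected to give about 100000 nM, between 30000 nM and 300000 nM. The expected step of a number no higher from compound 1 to compound 3 (the limit leaves the size open) is estimated as no real change.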

Compound 3, half-maximal inhibitory concentration: > 100000 nM
Compound 3: a limit, no number; the forecaster's own chance of this, stated with the estimate: 60%; the middle value sits exactly at the limit.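

Compound 1 and compound 3 both end at a limit rather than a number, so no step can be read between them: the limit of > 100000 nM in this assay, at which 2 of the 3 values shown sit.

The compounds shown leave open what fluoro in place of methoxy on an aromatic carbon does in this assay.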